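The source may report more compounds than this note shows. Statements on the series, on what has been measured and on what is new or still open speak of the compounds shown alone.

Compound 2 `CCn1c(C(=O)NCCN)ccc1C(CC)(CC)c1ccc(OCCC(O)(CC)CC)c(C)c1` gives the higher of the two numbers in a functional assay on HepG2 cells (Homo sapiens) for antiproliferative activity, read by MTT assay, with a stated time of 48 h (on this read-out higher numbers stand for weaker inhibition and lower numbers for stronger inhibition), standing at 1590 nM, while compound 1 `CCn1c(C(=O)NCCN(C)C)ccc1C(CC)(CC)c1ccc(OCCC(O)(CC)CC)c(C)c1` gives 240 nM. Within the data shown here, the one measured step, a 6.6-fold higher number from compound 1 to compound 2 (0.82 log units; beyond the scatter), shows that the group on the amide nitrogen matters on this read-out. Compound 3 `CCn1c(C(=O)N(C)CC(=O)O)ccc1C(CC)(CC)c1ccc(OCCC(O)(CC)CC)c(C)c1` carries the change ((carboxymethyl)(methyl)amino in place of (2-aminoethyl)amino on a carbonyl carbon). Among the measured compounds shown here, only that step bears on it, and it goes the other way in kind, so the direction is uncertain; a somewhat higher number is expected, a 2.2-fold higher number from compound 2 to compound 3 (0.34 log units; beyond the scatter), because in compound 2 the step of a 6.6-fold higher number from compound 1 to compound 2 (0.82 log units; beyond the scatter) already moved upward. Compound 3 is therefore estimated at 3500 nM, within 800 nM to 15000 nM.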

Compound 3, half-maximal inhibitory concentration: 5710 nM
Compound 3: the middle estimate sits 1.6-fold (0.21 log units) below what was measured; measured number inside the range.
By their numbers in this assay, from the lowest: compound 1; then compound 2; then compound 3.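

In this assay, (carboxymethyl)(methyl)amino on the carbonyl carbon gives a 3.6-fold higher number from compound 2 to compound 3 (0.56 log units; beyond the scatter) in place of (2-aminoethyl)amino, and a 24-fold higher number from compound 1 to compound 3 (1.38 log units; beyond the scatter) in place of (2-(dimethylamino)ethyl)amino. The whole group on this carbonyl carbon, not only the end of the chain, therefore moves the number, and the chain ending in a carboxylic acid stands above both chains ending in an amine. Nothing available explains these differences. The compounds shown change the carboxylic acid and the methyl on the amide nitrogen together, and their separate shares remain unknown. From the compounds shown here alone, how a methyl ester or a longer chain ending in dimethylamino would stand also remains open.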